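Series notes: substituent changes on the shared core

The source may hold more compounds than are shown below. What is called first, only, known or untested is meant among the compounds shown, and "the series" means these compounds.

Measured so far:
compound 1 `CN(Cc1ncnc2c1ncn2[C@@H]1O[C@H](CO)[C@@H](O)[C@H]1O)c1ccccc1` gives 3400 nM in a functional assay on HL-60 cells (Homo sapiens) for inhibition, read by XTT assay, with a stated time of 72 h; a higher number here means a weaker inhibitor, a lower number a stronger inhibitor
compound 2 `OC[C@H]1O[C@@H](n2cnc3c(COc4ccccn4)ncnc32)[C@H](O)[C@@H]1O` gives 14300 nM in this assay
compound 3 `CSCc1ncnc2c1ncn2[C@@H]1O[C@H](CO)[C@@H](O)[C@H]1O` gives 5000 nM in this assay

Compound 3 holds the second highest of the three numbers; its nearest neighbour is compound 1, and compound 2 lies furthest from it. Compound 4 `COCc1ncnc2c1ncn2[C@@H]1O[C@H](CO)[C@@H](O)[C@H]1O` differs from compound 3 by methoxy in place of methylsulfanyl on a saturated chain carbon bound to an aromatic carbon. Going by the values given here, the steps that bear on this site are a 1.5-fold higher number from compound 1 to compound 3 (0.17 log units; within the scatter) and a 2.9-fold lower number from compound 2 to compound 3 (0.46 log units; beyond the scatter), so exchanges here have moved the number only modestly and in no consistent direction. A step of similar small size is therefore expected, likely within the scatter, so that compound 4 is estimated at 6000 nM (range 2500 nM to 15000 nM), meaning an expected 1.2-fold higher number from compound 3 to compound 4 (0.08 log units; within the scatter).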

Compound 4, half-maximal inhibitory concentration: 1680 nM
Compound 4: middle estimate off by 3.6-fold (0.55 log units), on the high side; measured number below the stated range.
By their numbers in this assay, from the lowest: compound 4; then compounds 1 and 3 (each within the scatter of the next); then compound 2.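

At this position, exchanging sulfur for oxygen in the side chain is not a silent change (a 3.0-fold lower number from compound 3 to compound 4 (0.47 log units; beyond the scatter)). With the oxygen kept, methyl in place of pyridin-2-yl gives the largest step at this site (an 8.5-fold lower number from compound 2 to compound 4 (0.93 log units; beyond the scatter)), and methoxy also separates from methyl(phenyl)amino (a 2.0-fold lower number from compound 1 to compound 4 (0.31 log units; beyond the scatter)), leaving compound 4 the strongest inhibitor of the four in this assay. No measured evidence accounts for these steps.
Open, going by these compounds, is whether ethoxy, a longer ether chain, or a hydroxyl or primary amine in place of methoxy would lower the number further.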